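From isobutyl to 2-chlorobenzyl: one further step

This account rests on a few compounds, and the source may have more. Where it says the series, first, only, none or still open, it means among the compounds named here.

In an ADME assay on HepG2 cells (Homo sapiens) for cytotoxicity, read by MTT assay, with a stated time of 72 h (on this read-out lower numbers stand for higher toxicity in this test and higher numbers for lower toxicity in this test), the compounds read as follows
compound 1 `Cc1ccc(-c2cc3nc(N)[nH]c(=O)c3s2)cc1` gives "nd(insoluble)" (no result reported)
compound 2 `CCC(CC)Nc1nc2cc(-c3ccc(C)cc3)sc2c(=O)[nH]1` gives 101000 nM
compound 3 `Cc1ccc(-c2cc3nc(NCC(C)C)[nH]c(=O)c3s2)cc1` gives 21600 nM

Compound 3 holds the lower of the two numbers available. Compound 4 `Cc1ccc(-c2cc3nc(NCc4ccccc4Cl)[nH]c(=O)c3s2)cc1` keeps the shared core and differs from it by 2-chlorophenyl in place of isopropyl on a saturated chain carbon bound to a nitrogen on an aromatic ring, which reads as isobutyl to 2-chlorobenzyl. Going by the values given here, only one measured step bears on this change, a 4.7-fold lower number from compound 2 to compound 3 (0.67 log units; beyond the scatter), and it alters the same nitrogen substituent. Among the compounds with values here, no measured compound carries a ring on that chain, so this step guides size only loosely. A modest move toward a lower number in this assay is therefore expected, namely a 2.4-fold lower number from compound 3 to compound 4 (0.38 log units; beyond the scatter). For compound 4 the estimated value is 9000 nM, with an expected range from 3000 nM to 30000 nM.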

Compound 4, half-maximal cytotoxic concentration: 32600 nM
Compound 4: middle estimate off by 3.6-fold (0.56 log units), on the low side; the whole stated range lies below it.
By their numbers in this assay, from the lowest: compounds 3 and 4 (each within the scatter of the next); then compound 2.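

In this assay the swap to 2-chlorophenyl in place of isopropyl on a saturated chain carbon bound to a nitrogen on an aromatic ring is a 1.5-fold higher number from compound 3 to compound 4 (0.18 log units; within the scatter) and stays within the scatter, so a six-membered aromatic ring there reads alike to the open chain. Set against pentan-3-yl, the 2-chlorobenzyl group shows a 3.1-fold lower number from compound 2 to compound 4 (0.49 log units; beyond the scatter) and lies beyond the scatter, as isobutyl did. No evidence at hand accounts for these readings. Open remains how an amine, a carboxylic acid, a longer chain or plain benzyl would read at this place.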